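This account rests on a few compounds, and the source may have more. Where it says the series, first, only, none or still open, it means among the compounds named here.

Two measured compounds share one core and differ only in the group carried on the benzyl arm. Compound 1, `Nc1ccccc1Cn1cc(CCCCC[C@@H]2SC[C@@H]3NC(=O)N[C@@H]32)nn1`, was tested in an assay on isolated protein for inhibition of biotin--protein ligase (Homo sapiens), read by scintillation counting, with a stated time of 10 min; a lower number here means a stronger inhibitor, a higher number a weaker inhibitor. In this assay compound 1 gives > 16000 nM, which is a limit of the assay and not a number. Compound 2, `O=C1N[C@H]2[C@H](CS[C@H]2CCCCCc2cn(Cc3ccccc3F)nn2)N1`, is the other measured compound. In this assay compound 2 gives > 16000 nM, likewise a limit of the assay rather than a number. The step that the two limits leave unreadable from compound 1 to compound 2 cannot be read in size, since both ends sit at the limit of > 16000 nM in this assay, at which 2 of the 2 values shown sit. Compound 2 therefore stands at a limit, with no number of its own on the scale. Compound 3, `O=C1N[C@H]2[C@H](CS[C@H]2CCCCCc2cn(Cc3cccc(Cl)c3)nn2)N1`, has not been measured; it differs from compound 2 by 3-chlorophenyl in place of 2-fluorophenyl on a saturated chain carbon bound to an aromatic nitrogen. Among the compounds with values here, no measured step bears on this change directly: the only measured step is unreadable, and both recorded values are limits. No direction beyond the scatter can be expected in this assay from such a pair. Compound 3 is expected to remain weak, at about 22000 nM, between 8000 nM and 60000 nM, and the step that the limit leaves unreadable from compound 2 to compound 3 is expected to stay within the scatter.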

Compound 3, inhibition constant: > 16000 nM
Compound 3: a limit, no number; the forecaster's own chance of this, stated with the estimate: 75%; the middle value lies beyond the limit too.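

In this assay compound 3 gives > 16000 nM, a limit of the assay and not a number. Within the data shown here, no step among compound 1, compound 2 and compound 3 can be read in size, as all three sit at one limit: the limit of > 16000 nM in this assay, at which 3 of the 3 values shown sit. The compounds shown leave open whether any group on the benzyl arm of the shared core would give a readable inhibition constant in this assay.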